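Swapping Methoxy for Nitro on the Shared Core

This account rests on a few compounds, and the source may have more. Where it says the series, first, only, none or still open, it means among the compounds named here.

Measured so far, in an assay for inhibition of Polyunsaturated fatty acid 5-lipoxygenase (Homo sapiens), read by spectrophotometry, tested at 10 uM; a higher number here means more inhibition at the concentration tested (going by the name of the read-out), a lower number less inhibition:
compound 1, `O=C(c1ccccc1)c1sc(N(c2ccccc2)c2ccccc2)nc1-c1ccccc1`, gives 48.6%
compound 2, `COc1ccc(-c2nc(N3CCCCC3)sc2C(=O)c2ccccc2)cc1`, gives 62%
compound 3, `COc1ccc(-c2nc(N(c3ccccc3)c3ccccc3)sc2C(=O)c2ccccc2)cc1`, gives 92.8%

Compound 3 stands highest of the three numbers in this assay. Within the data shown here, its nearest neighbour is compound 2, whose value is lower by more than the usual scatter; compound 1 is furthest away, and the only single change measured here is a number 44.2 percentage points higher from compound 1 to compound 3 (beyond the scatter), a large gain.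

Compound 4, `O=C(c1ccccc1)c1sc(N(c2ccccc2)c2ccccc2)nc1-c1ccc([N+](=O)[O-])cc1`, has not been measured. It differs from compound 3 in one place: nitro in place of methoxy on an aromatic carbon.

Among the measured compounds shown here, the one measured step that touches this position is a number 44.2 percentage points higher from compound 1 to compound 3 (beyond the scatter). That is the gain in the number that came with the methoxy entering. In compound 4 that methoxy leaves, so part of that gain is expected to be lost, while nothing measured here speaks to a nitro group at this position. The expected step is therefore downward and moderate, a number 27.8 percentage points lower from compound 3 to compound 4 (beyond the scatter), with wide uncertainty. Compound 4 is estimated at 65% in this assay, within a range from 40% to 90%.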

Compound 4, a percentage reported as inhibition, at one concentration (the size of the read-out at that concentration, not a potency): 79.6%
The estimate for compound 4 lay 14.6 percentage points below the measured number; the measured number falls inside the stated range.
By their numbers in this assay, from the lowest: compound 1; then compound 2; then compound 4; then compound 3.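

In this assay, the gain at this position does not belong to methoxy alone: nitro on the same aromatic carbon, para to a large group, also beats hydrogen, giving a number 31 percentage points higher from compound 1 to compound 4 (beyond the scatter). The choice of group still matters, since replacing methoxy with nitro gives a number 13.2 percentage points lower from compound 3 to compound 4 (beyond the scatter), a modest step beside the large rise that either group brings over hydrogen. Nothing available here explains why these two different groups both raise the number.

An amine, a carboxylic acid or a plain methyl on this carbon could tell whether almost any group in this place raises the number or only some do. As far as these compounds go, it also remains open whether nitro would give a similar rise when the diphenylamino group is replaced by the ring carried by compound 2.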